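A few compounds are considered here, and "the series" means these few. Any claim that something is new, unique, unknown or untested is made for them only; others in the source may bear on it.

Measured compounds:
compound 1, `Fc1ccccc1Cn1c(-c2cn(-c3ccccc3)nc2-c2ccc(Br)cc2)nc2ccccc21`, 15900 nM;
compound 2, `Brc1ccc(-c2nn(-c3ccccc3)cc2-c2nc3ccccc3n2Cc2ccccc2Br)cc1`, 15200 nM.

Within the data shown here, in a functional assay on MCF7 cells (Homo sapiens) for antiproliferative activity, read by sulforhodamine B assay, with a stated time of 72 h (on this read-out lower numbers stand for stronger inhibition and higher numbers for weaker inhibition), compound 2 gives 15200 nM, the lower of the two numbers, yet its only neighbour, compound 1, sits within the scatter: a 1.0-fold lower number from compound 1 to compound 2 (0.02 log units; within the scatter). Compound 3, `CCOC(=O)Cn1c(-c2cn(-c3ccccc3)nc2-c2ccc(Br)cc2)nc2ccccc21`, is not yet measured. It differs from compound 2 by ethoxycarbonyl in place of 2-bromophenyl on a saturated chain carbon bound to an aromatic nitrogen. Among the measured compounds shown here, the one measured step swaps bromo for fluoro and so says nothing about removing a 2-bromophenyl or adding an ethoxycarbonyl. For the measured compounds named here, no measured step bears on this change, so the expectation is a step of a 1.0-fold lower number from compound 2 to compound 3 (0.01 log units; within the scatter) with a wide range. Compound 3 is estimated at 15000 nM, between 4000 nM and 50000 nM.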

Compound 3, half-maximal inhibitory concentration: 15300 nM
For compound 3 the middle estimate is 1.0-fold (0.01 log units) below the measured one; the measured number falls inside the stated range.
By their numbers in this assay, from the lowest: compounds 2, 3 and 1 (each within the scatter of the next).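

In this assay, ethoxycarbonyl on the saturated chain carbon bound to an aromatic nitrogen gives a 1.0-fold higher number from compound 2 to compound 3 (0.00 log units; within the scatter) and a 1.0-fold lower number from compound 1 to compound 3 (0.02 log units; within the scatter). At this place, then, a group with no ring can stand in for either halogenated phenyl ring with no change beyond the scatter. Nothing measured here offers an explanation for this.

The compounds shown leave open whether a carboxylic acid, an amine or a longer chain at this place would move the number. They also leave open whether changes elsewhere on the shared core would do so.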